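From phenyl to 3-nitrophenyl on a shared core

The compounds below may be only part of what the source reports. "The series", "measured", "known", "first", "only" and "open" are said of these compounds alone.

- compound 1 `C[C@H]1CC[C@@H]2[C@@H](OC(=O)[C@]23CC(c2c(Cl)cccc2Cl)=NO3)[C@]2(C)C(=O)C=C[C@@]12O` gives 56000 nM
- compound 2 `C[C@H]1CC[C@@H]2[C@@H](OC(=O)[C@]23CC(c2ccc(Cl)cc2)=NO3)[C@]2(C)C(=O)C=C[C@@]12O` gives 49000 nM
- compound 3 `C[C@H]1CC[C@@H]2[C@@H](OC(=O)[C@]23CC(c2ccccc2)=NO3)[C@]2(C)C(=O)C=C[C@@]12O` gives 46000 nM

These three compounds were measured in a functional assay on PC-3 cells (Homo sapiens) for cytotoxicity, read by sulforhodamine B assay, with a stated time of 48 h (on this read-out lower numbers stand for stronger inhibition and higher numbers for weaker inhibition), and differ only in the aromatic group on the carbon with a double bond to nitrogen. Compound 3 at 46000 nM stands within the scatter of both others. Compound 4 `C[C@H]1CC[C@@H]2[C@@H](OC(=O)[C@]23CC(c2cccc([N+](=O)[O-])c2)=NO3)[C@]2(C)C(=O)C=C[C@@]12O` carries nitro in place of hydrogen on an aromatic carbon, meta to a large group (nitro in place of hydrogen on an aromatic carbon), so phenyl becomes 3-nitrophenyl. Among the measured compounds shown here, two measured steps concern substitution on this same aromatic ring (a 1.1-fold lower number from compound 2 to compound 3 (0.03 log units; within the scatter) and a 1.2-fold lower number from compound 1 to compound 3 (0.09 log units; within the scatter)), and both lie within the scatter. Neither brings in nitro, so they offer no direct guide to this group, and the range must stay wide. No step beyond the scatter is expected in this assay and no direction can be argued. The estimated step (a 1.0-fold lower number from compound 3 to compound 4 (0.01 log units; within the scatter)) is therefore small. Compound 4 is expected near 45000 nM with an estimated range from 20000 nM to 90000 nM in this series.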

Compound 4, half-maximal inhibitory concentration: 55000 nM
The estimate for compound 4 lay 1.2-fold (0.09 log units) below the measured number, within the range that was stated.
By their numbers in this assay, from the lowest: compounds 3, 2, 4 and 1 (each within the scatter of the next).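

Compound 4 shows in this assay that nitro on an aromatic carbon, meta to a large group, also leaves the number within the scatter of the unsubstituted phenyl (a 1.2-fold higher number from compound 3 to compound 4 (0.08 log units; within the scatter)). The comparisons with the two chlorinated rings read the same way (a 1.1-fold higher number from compound 2 to compound 4 (0.05 log units; within the scatter); a 1.0-fold lower number from compound 1 to compound 4 (0.01 log units; within the scatter)), so all four aromatic groups on the shared core now lie within the scatter of one another, and a group other than chloro has made no measurable difference at this ring. Nothing measured here offers an explanation for this flat result.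

The compounds shown leave open whether an amine, a carboxylic acid or a hydroxyl group on this ring would move the number beyond the scatter. They also leave open whether replacing the aromatic ring with a longer alkyl chain would do so.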